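This account rests on a few compounds, and the source may have more. Where it says the series, first, only, none or still open, it means among the compounds named here.

Measured so far in a functional assay on the whole organism with Mus musculus as the target, in the maximal electroshock model, with a stated time of 0.5 h; on this read-out lower numbers stand for an effect already at smaller amounts and higher numbers for an effect only at larger amounts of compound:
compound 1 `O=C(N/N=C/c1ccccc1[N+](=O)[O-])Nc1ccc(Br)cc1` gives 300 mg/kg
compound 2 `CNC(=S)Nc1ccc(S(=O)(=O)Nc2ccc(Cl)cc2)cc1` gives 300 mg/kg
compound 3 `Cc1ccc(NC(=S)Nc2ccc(S(=O)(=O)Nc3ccc(Cl)cc3)cc2)cc1` gives 100 mg/kg

Compound 3 holds the lowest number of the three; compound 1 and compound 2 each sit higher, and both gaps lie beyond the scatter. Among the measured compounds shown here, the only step measured, a 3.0-fold lower number from compound 2 to compound 3 (0.48 log units; beyond the scatter), concerns the group on an amide-type nitrogen and not the part altered here. Compound 4 `Cc1ccc(NC(=S)Nc2ccc(S(=O)(=O)Nc3ccc(C)cc3)cc2)cc1` differs from compound 3 in one place: methyl in place of chloro on an aromatic carbon. For the measured compounds named here, no measured step bears on this exchange, and the values of compound 1 and compound 2 say nothing about it either. With nothing to fix a direction, the expected step is none beyond the scatter, no change at the digits printed from compound 3 to compound 4 (within the scatter). Compound 4 is therefore estimated at 100 mg/kg in this assay, with a range from 30 mg/kg to 300 mg/kg.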

Compound 4, minimum effective dose: 300 mg/kg
The estimate for compound 4 lay 3.0-fold (0.48 log units) below the measured number; the range from low to high includes it.
By their numbers in this assay, from the lowest: compound 3; then compounds 1, 2 and 4 (each within the scatter of the next).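

In this assay, the place on the aromatic carbon para to a large group proves sensitive to the group it carries: methyl in place of chloro gives a 3.0-fold higher number from compound 3 to compound 4 (0.48 log units; beyond the scatter). This single pair favours the 4-chlorophenyl group over the 4-methylphenyl group, with the other 4-methylphenyl group on the amide-type nitrogen held constant. Nothing available explains this step.

The compounds shown leave open how a fluoro, a methoxy or an amine would read at this place. They also leave open whether the same step holds with methyl in place of 4-methylphenyl on the amide-type nitrogen.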